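A few compounds are considered here, and "the series" means these few. Any claim that something is new, unique, unknown or untested is made for them only; others in the source may bear on it.

Measured compounds:

Compound 1 `Cc1ccc(-c2nc3ccccc3o2)cc1NC(=O)c1cc([N+](=O)[O-])ccc1Cl` — in an ADME assay for permeability, using PAMPA, at pH 7.4 (a lower number here means that the compound crosses the layer more slowly, a higher number that the compound crosses the layer faster), compound 1 gives "below limit of detection" (no number reported).

Compound 2 `Cc1ccc(-c2nc3ccccc3s2)cc1NC(=O)c1cc([N+](=O)[O-])c(N2CCCCC2)cc1Cl` — in this assay compound 2 gives < 1 10^-6 cm/s.

Both values are limits of the assay rather than numbers. Compound 1 has no single number in this assay: its read-out is a limit. Compound 2 also sits at a limit, (the limit of < 1 10^-6 cm/s in this assay, at which 1 of the 2 values shown sits), so neither value can be set against the other as a measured step, and the two only show that both compounds cross the layer very slowly, if at all.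

Compound 3 `O=C(Nc1cc(-c2nc3ccccc3o2)ccc1F)c1cc([N+](=O)[O-])ccc1Cl` has not yet been measured in this assay. It differs from compound 1 in one place: fluoro in place of methyl on an aromatic carbon. The rest of the shared core, with its amide, its nitro group and its chloro, is kept.

Among the measured compounds shown here, with compound 1 at a limit and no measured step between two compounds to draw on, no direction can be read from the data. The expectation is that the change from compound 1 to compound 3 produces no step beyond the scatter in this assay, and that compound 3 remains near the limit as well. Compound 3 is therefore estimated at 0.5 10^-6 cm/s, within a range from 0.1 10^-6 cm/s to 2 10^-6 cm/s, with a good chance that only a limit is reported.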

Compound 3, apparent permeability: 214 10^-6 cm/s
The estimate for compound 3 lay 430-fold (2.63 log units) below the measured number, outside the stated range (above it).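

Among the compounds shown here, compound 1 has only a limit in this assay, not a number, so no step from it to compound 3 can be read. Nothing shown accounts for the value of compound 3. The compounds shown leave open how far fluoro in place of methyl truly moves this read-out, and whether it would do the same on other compounds.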